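Swapping 3-nitrophenyl for 4-fluorophenyl in a cytotoxic series

The source may hold more compounds than are shown below. What is called first, only, known or untested is meant among the compounds shown, and "the series" means these compounds.

Compound 1 `COc1cc(C2=NO[C@]3(C2)C(=O)O[C@@H]2[C@H]3CC[C@H](C)[C@]3(O)C=CC(=O)[C@@]23C)ccc1O` gives 16000 nM
Compound 2 `C[C@H]1CC[C@@H]2[C@@H](OC(=O)[C@]23CC(c2ccccc2F)=NO3)[C@]2(C)C(=O)C=C[C@@]12O` gives 8200 nM
Compound 3 `C[C@H]1CC[C@@H]2[C@@H](OC(=O)[C@]23CC(c2cccc([N+](=O)[O-])c2)=NO3)[C@]2(C)C(=O)C=C[C@@]12O` gives 55000 nM

All three were tested in a functional assay on PC-3 cells (Homo sapiens) for cytotoxicity, read by sulforhodamine B assay, with a stated time of 48 h (a lower number here means a stronger inhibitor, a higher number a weaker inhibitor), and compound 3 stands highest, making it the weakest of the three. The measurements show a 3.4-fold higher number from compound 1 to compound 3 (0.54 log units; beyond the scatter) and a 6.7-fold higher number from compound 2 to compound 3 (0.83 log units; beyond the scatter) in this small set. Compound 4 `C[C@H]1CC[C@@H]2[C@@H](OC(=O)[C@]23CC(c2ccc(F)cc2)=NO3)[C@]2(C)C(=O)C=C[C@@]12O` has not yet been measured. It carries 4-fluorophenyl in place of 3-nitrophenyl on a carbon with a double bond to nitrogen. The closest guide is a 6.7-fold higher number from compound 2 to compound 3 (0.83 log units; beyond the scatter) with 3-nitrophenyl in place of 2-fluorophenyl, read here in reverse. The other guide is a 2.0-fold lower number from compound 1 to compound 2 (0.29 log units; within the scatter) and shows that compound 1 and compound 2 do not separate. Going by the values given here, no compound with 4-fluorophenyl has been measured, so a somewhat smaller step towards a lower number is expected, not a full return to compound 2. The step expected in this assay is a 4.6-fold lower number from compound 3 to compound 4 (0.66 log units; beyond the scatter) as an estimate. For compound 4 the estimated value is 12000 nM with an expected range from 4500 nM to 32000 nM (an estimate only).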

Compound 4, half-maximal inhibitory concentration: 27000 nM
Beside the measured number, compound 4's estimate is 2.3-fold (0.35 log units) below it, and the stated range covers the measured number.
By their numbers in this assay, from the lowest: compounds 2, 1 and 4 (each within the scatter of the next, the first and the last beyond it); then compound 3.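

In this assay, this position on the carbon with a double bond to nitrogen now shows that two fluorophenyl groups can separate: 4-fluorophenyl in place of 2-fluorophenyl gives a 3.3-fold higher number from compound 2 to compound 4 (0.52 log units; beyond the scatter) and so loses part of what compound 2 held. Replacing 3-nitrophenyl with 4-fluorophenyl gives a 2.0-fold lower number from compound 3 to compound 4 (0.31 log units; beyond the scatter) as a modest gain, while replacing 4-hydroxy-3-methoxyphenyl with 4-fluorophenyl gives a 1.7-fold higher number from compound 1 to compound 4 (0.23 log units; within the scatter) and does not separate the two compounds. No measurement at hand accounts for any of these steps.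

The compounds shown leave open where 3-fluorophenyl would fall relative to compound 2 and compound 4, and how plain phenyl would compare with them. They also leave open whether an amine or a carboxylic acid on the phenyl ring would move the number at all.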